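A few compounds are considered here, and "the series" means these few. Any claim that something is new, unique, unknown or untested is made for them only; others in the source may bear on it.

Measured compounds and their values in an assay on isolated protein for inhibition of long-chain fatty acid transport protein 1 (Homo sapiens); on this read-out higher numbers stand for weaker inhibition and lower numbers for stronger inhibition:
- compound 1 `CCc1ccc2oc(CSc3nnc(CNc4ccccc4)n3CC)nc2c1`: in this assay compound 1 gives only a limit of the assay, > 1000 nM.
- compound 2 `CCn1c(CNc2ccccc2)nnc1SCC(=O)Nc1ccc(C(C)=O)cc1`: in this assay compound 2 gives only a limit of the assay, > 1000 nM.
- compound 3 `CCn1c(CNc2ccccc2)nnc1SCc1nc2cc(OC(F)(F)F)ccc2o1`: in this assay compound 3 gives 100 nM.

Of the three values in this assay, two are limits rather than numbers, and compound 2 stands at that limit (the limit of > 1000 nM in this assay, at which 2 of the 3 values shown sit). Among the compounds with values here, the single measured step, an at least 10-fold lower number from compound 1 to compound 3 (1.00 log units; beyond the scatter), concerns a change at a different place, so it does not bear directly on the step now considered.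

Compound 4 `CCn1c(CNc2ccccc2)nnc1SCC(=O)Nc1ccc(Cl)cc1` has not yet been measured. It differs from compound 2 by chloro in place of acetyl on an aromatic carbon. Within the data shown here, with compound 2 known only as a limit and no measured step on this change, the expectation for compound 4 has little to rest on. The step that the limit leaves unreadable from compound 2 to compound 4 is therefore estimated to be none beyond the scatter. In this assay compound 4 is expected to give about 2000 nM, somewhere between 500 nM and 10000 nM, with a considerable chance that only a limit is reported again.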

Compound 4, half-maximal inhibitory concentration: > 1000 nM
Compound 4: only a limit was reported; the forecaster's own chance of this, stated with the estimate: 65%; the middle value is on the limit's open side.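

Compound 2 and compound 4 each give only a limit of the assay, not a number, so no step can be read between them: the limit of > 1000 nM in this assay, at which 3 of the 4 values shown sit.

The compounds shown leave open how strongly either compound inhibits, and whether chloro in place of acetyl makes any difference.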